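Working notes on the amide substituent: compound 4

A few compounds are considered here, and "the series" means these few. Any claim that something is new, unique, unknown or untested is made for them only; others in the source may bear on it.

compound 1 `O=C(Nc1cc(F)cc2c(=O)cc(C(=O)O)oc12)c1ccc(Cl)c(Cl)c1`: 2650 nM
compound 2 `COc1ccc(C(=O)Nc2cc(Br)cc3c(=O)cc(C(=O)O)oc23)cn1`: 991 nM
compound 3 `COc1ccc(C(=O)Nc2cccc3c(=O)cc(C(=O)O)oc23)cc1`: 2160 nM

All three were measured in an assay on CHO cells for agonist activity at G protein-coupled receptor GPR35 (Rattus norvegicus), read by a beta-galactosidase reporter and beta-arrestin recruitment, with a stated time of 90 min; a lower number here means that less compound is needed, a higher number that more compound is needed for the effect. Compound 2 gives the lowest number of the three; the gap to compound 3, the nearest, and the larger gap to compound 1 both lie beyond the usual scatter, so compound 2 is the most potent measured compound. Compound 4 `COc1ccccc1C(=O)Nc1cc(Br)cc2c(=O)cc(C(=O)O)oc12` has not been measured. It differs from compound 2 in one place: 2-methoxyphenyl in place of 6-methoxypyridin-3-yl on a carbonyl carbon. Going by the values given here, no two measured compounds differ in a single place, so no step of this kind is known directly. Among the compounds with values here, the only guide is compound 3, which also carries a methoxy-bearing carbon-only ring on the amide but differs from compound 2 in several places at once. In this assay compound 3 gives 2160 nM. Compound 2 gives 991 nM, a lower number.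

Given this, the step of a 1.6-fold higher number from compound 2 to compound 4 (0.21 log units; within the scatter) is expected to be a modest rise, roughly at the edge of the scatter rather than a large loss. For compound 4 the estimated value is 1600 nM, with a range from 500 nM to 5000 nM.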

Compound 4, half-maximal effective concentration: 1100 nM
Compound 4: middle estimate off by 1.5-fold (0.16 log units), on the high side; the range from low to high includes it.
By their numbers in this assay, from the lowest: compounds 2, 4, 3 and 1 (each within the scatter of the next, the first and the last beyond it).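

In this assay, replacing 6-methoxypyridin-3-yl with 2-methoxyphenyl on a carbonyl carbon gives a 1.1-fold higher number from compound 2 to compound 4 (0.05 log units; within the scatter), so compound 2 and compound 4 cannot be told apart. Going by these compounds alone, this is the first direct reading at this place, and it shows that, on the shared core of this pair, the aromatic ring of carbon only matches the ring with a hetero atom, even though the ring atoms and the attachment of the methoxy group both differ. No measurement is available to explain this match, and no cause can be assigned to it.

The pair changes the ring nitrogen and the methoxy placement together, so it cannot show whether each change alone would leave the number unchanged or whether two separate effects happen to cancel. It also leaves open how this place responds to groups further from these two, such as a phenyl ring with no methoxy group, a saturated piperidine ring carrying an amine nitrogen, or a longer alkyl chain on the carbonyl carbon.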